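The compounds below may be only part of what the source reports. "The series", "measured", "known", "first", "only" and "open" are said of these compounds alone.

Measured compounds:
compound 1 `COc1ccc(C(=O)/C=C/c2cc3ccccc3[nH]c2=O)cc1` — 5700 nM
compound 2 `O=C(/C=C/c1cc2ccccc2[nH]c1=O)c1ccc(O)cc1` — 4380 nM

Both numbers come from a functional assay on HCT-116 cells (Homo sapiens) for cytotoxicity, read by sulforhodamine B assay, with a stated time of 24 h; a lower number here means a stronger inhibitor of growth, a higher number a weaker inhibitor of growth. Among the measured compounds shown here, the only comparison available is the step of a 1.3-fold lower number from compound 1 to compound 2 (0.11 log units; within the scatter), so compound 2 and compound 1 sit within the usual scatter of each other and neither can be set apart on these numbers.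

Compound 3 `O=C(/C=C/c1cc2ccccc2[nH]c1=O)c1ccc(Cl)cc1` differs from compound 2 by one exchange: chloro in place of hydroxy on an aromatic carbon. For the measured compounds named here, the one measured step, a 1.3-fold lower number from compound 1 to compound 2 (0.11 log units; within the scatter), changed the same position in a different way and stayed within the scatter, which suggests that this position tolerates small alterations without a large effect. Going by the values given here, no measured step exchanges hydroxy for chloro, so the direction of any change is unknown. Compound 3 is therefore expected to land near compound 2, with a step of about a 1.1-fold lower number from compound 2 to compound 3 (0.04 log units; within the scatter), and an estimated value of 4000 nM, between 1500 nM and 11000 nM.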

Compound 3, concentration for total growth inhibition: 14800 nM
The estimate for compound 3 lay 3.7-fold (0.57 log units) below the measured number, outside the stated range (above it).
By their numbers in this assay, from the lowest: compounds 2 and 1 (each within the scatter of the next); then compound 3.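

In this assay, chloro in place of hydroxy gives a 3.4-fold higher number from compound 2 to compound 3 (0.53 log units; beyond the scatter), and chloro in place of methoxy gives a 2.6-fold higher number from compound 1 to compound 3 (0.41 log units; beyond the scatter). This position therefore does not tolerate every exchange: hydroxy and methoxy stayed within the scatter of each other, but with chloro on the same aromatic carbon, compound 3 is a weaker inhibitor of growth than either oxygen-linked compound. Nothing available explains this difference between chloro and the two oxygen-linked groups.

The compounds shown leave open whether the higher number goes with the arrival of chlorine or with the absence of an oxygen at this position. They also do not show how an amine or a fluoro group on this aromatic carbon would compare, or how changes elsewhere on the shared core would read.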